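The source may hold more compounds than are shown below. What is called first, only, known or untested is meant among the compounds shown, and "the series" means these compounds.

Compound 1 `COc1c(F)ccc2c1c(NS(=O)(=O)c1ccc(Cl)s1)nn2Cc1cccc(CNC(C)=O)c1` and compound 2 `COc1c(F)ccc2c1c(NS(=O)(=O)c1ccc(Cl)s1)nn2Cc1cccc(CNC(=O)C(C)(C)O)c1` share one core; compound 3 `COc1cc(F)cc2c1c(NS(=O)(=O)c1ccc(Cl)s1)nn2Cc1cccc(CNC(C)=O)c1` and compound 4 `COc1cc(F)cc2c1c(NS(=O)(=O)c1ccc(Cl)s1)nn2Cc1cccc(CNC(=O)C(C)(C)O)c1` share another, and the difference between the two cores is not broken down here. In a physicochemical assay for lipophilicity (a lower number here means a more polar compound, a higher number a more lipophilic compound), compound 1 gives 4.1, compound 2 gives 4.1 and compound 3 gives 4.1. The change 1-hydroxy-1-methylethyl in place of methyl on a carbonyl carbon moved this assay by no change at the digits printed from compound 1 to compound 2 (within the scatter). The change 1-hydroxy-1-methylethyl in place of methyl on a carbonyl carbon is the same change, made on the same place. Because the earlier instance gave no change at the digits printed from compound 1 to compound 2 (within the scatter), the step from compound 3 to compound 4 is expected to be no change at the digits printed from compound 3 to compound 4 (within the scatter) in this assay. Compound 4 is therefore estimated at 4.1 in this assay, with a range from 3.8 to 4.4.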

Compound 4, distribution coefficient: 4.2
Compound 4: middle estimate off by 0.10 log units, on the low side, and the stated range covers the measured number.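

In this assay, putting 1-hydroxy-1-methylethyl in place of methyl on a carbonyl carbon gave no change at the digits printed from compound 1 to compound 2 (within the scatter) on one core and a number 0.10 log units higher from compound 3 to compound 4 (within the scatter) on the other. Across these two cores, the change carried over with both steps within the scatter, but this does not show that it would behave the same way on a further core or in a different assay. No evidence on the cause of this result is given here.

The compounds shown carry only methyl or 1-hydroxy-1-methylethyl on that carbonyl carbon. They leave open how an amine, a carboxylic acid or a longer chain in that place would read in this assay on either core.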